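A few compounds are considered here, and "the series" means these few. Any claim that something is new, unique, unknown or untested is made for them only; others in the source may bear on it.

Compounds measured so far:
compound 1 `Cn1c(=O)c(S(=O)(=O)c2ccc(F)cc2F)cc2cnc(Nc3ccc4[nH]c(C(=O)O)cc4c3)nc21`: 10000 nM
compound 2 `COc1ccc(S(=O)(=O)c2cc3cnc(Nc4ccc5[nH]ccc5c4)nc3n(C)c2=O)cc1`: 300 nM
compound 3 `Cn1c(=O)c(S(=O)(=O)c2ccc(OC(=O)CCCCC3SCC4NC(=O)NC43)cc2)cc2cnc(Nc3ccc4[nH]ccc4c3)nc21`: 600 nM

In a functional assay on K562 cells (Homo sapiens) for inhibition, read by trypan blue exclusion, with a stated time of 72 h (a higher number here means a weaker inhibitor, a lower number a stronger inhibitor), compound 1 gives 10000 nM, the highest of the three numbers. Compound 3 stands nearest to it at 600 nM, a gap that lies beyond the scatter, and compound 2 stands furthest at 300 nM, also beyond the scatter. Compound 1 is therefore the weakest inhibitor of the three on these numbers.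

Compound 4 `Cn1c(=O)c(S(=O)(=O)c2ccc(F)cc2F)cc2cnc(Nc3cnc4[nH]ccc4c3)nc21` has not yet been measured. It differs from compound 1 in one place:

a group of 9 heavy atoms (7 carbon, 2 nitrogen; one five-membered aromatic ring with 1 hetero atom, one six-membered aromatic ring with 1 hetero atom) in place of a group of 12 heavy atoms (9 carbon, 1 nitrogen, 2 oxygen; one five-membered aromatic ring with 1 hetero atom, one six-membered aromatic ring of carbon only), on a nitrogen on an aromatic ring

The group that leaves carries the carboxylic acid that neither compound 2 nor compound 3 possesses, and both of those give lower numbers than compound 1. For the measured compounds named here, no step between measured compounds is available for this exact change, so the expectation rests on that comparison alone. A step toward stronger inhibition is expected, of a size comparable to the gaps from compound 1 to compound 2 and compound 3, which the estimate a 17-fold lower number from compound 1 to compound 4 (1.22 log units; beyond the scatter) expresses. For compound 4 in this assay the estimated value is 600 nM, with a range from 150 nM to 3000 nM.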

Compound 4, half-maximal inhibitory concentration: 750 nM
Estimate against measurement, compound 4: 1.3-fold (0.10 log units) below, within the range that was stated.
By their numbers in this assay, from the lowest: compounds 2, 3 and 4 (each within the scatter of the next, the first and the last beyond it); then compound 1.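

In this assay, exchanging the group on the nitrogen on an aromatic ring gives a 13-fold lower number from compound 1 to compound 4 (1.12 log units; beyond the scatter) while the rest of compound 1 stays unchanged, and this is the only step shown that isolates this position. It shows that the 2-carboxy-1H-indol-5-yl group is not needed there for a number in the range of compound 4, since a group without the carboxylic acid and with one hetero atom in its six-membered ring gives a much lower number. No measurement at hand bears on the reason for this step.

The exchange alters the carboxylic acid and the six-membered ring together, and no pair shown separates their shares of the step. From the compounds shown here alone, it also remains open how a methyl ester or a primary amide in place of the carboxylic acid would read at this position.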